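A few compounds are considered here, and "the series" means these few. Any claim that something is new, unique, unknown or untested is made for them only; others in the source may bear on it.

Compound 2 `CCCCCCCCCCCCCCCCCCNC(=O)[C@H]1CSC(C2CCCCC2)N1` stands second highest among the three numbers measured in a functional assay on PPC-1 cells (Homo sapiens) for antiproliferative activity, read by sulforhodamine B assay (on this read-out lower numbers stand for stronger inhibition and higher numbers for weaker inhibition), where compound 2 gives 9300 nM. Its nearest neighbour is compound 1 `CCCCCCCCCCCCCCCCCCNC(=O)[C@H]1CSC(CCCCCCCCCCCC)N1`, which in this assay gives 13000 nM, a gap of a 1.4-fold lower number from compound 1 to compound 2 (0.15 log units; within the scatter). Further away lies compound 3 `CCCCCCCCCCCCCCCCCCNC(=O)[C@H]1CSC(Cc2ccccc2)N1`, which in this assay gives 4000 nM, reached by a 2.3-fold lower number from compound 2 to compound 3 (0.37 log units; beyond the scatter).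

Compound 4 `CCCCCCCCCCCCCCCCCCNC(=O)[C@H]1CSC(c2ccc(C)cc2)N1` differs from compound 2 in one place: 4-methylphenyl in place of cyclohexyl on a saturated ring carbon. Within the data shown here, two measured steps bear on this change. The step of a 2.3-fold lower number from compound 2 to compound 3 (0.37 log units; beyond the scatter) put an aromatic ring onto the same saturated ring carbon, though through a benzyl group rather than directly. The step of a 3.3-fold lower number from compound 1 to compound 3 (0.51 log units; beyond the scatter) likewise traded a saturated chain for an aromatic ring. Both were modest and in the same direction, so a modest lowering of the number is expected for compound 4 as well, not a large one, given that neither step used a 4-methylphenyl attached directly to the ring carbon.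

Compound 4 is therefore expected to give about 5000 nM in this assay, within a range from 2500 nM to 10000 nM, corresponding to an expected step of a 1.9-fold lower number from compound 2 to compound 4 (0.27 log units; within the scatter).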

Compound 4, half-maximal inhibitory concentration: 1900 nM
Compound 4: middle estimate off by 2.6-fold (0.42 log units), on the high side; measured number outside the range, below it.
By their numbers in this assay, from the lowest: compound 4; then compound 3; then compounds 2 and 1 (each within the scatter of the next).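

Among these compounds, at the saturated ring carbon next to the ring nitrogen and the ring sulfur, 4-methylphenyl gives the lowest number so far in this assay, with a 4.9-fold lower number from compound 2 to compound 4 (0.69 log units; beyond the scatter) and a 6.8-fold lower number from compound 1 to compound 4 (0.84 log units; beyond the scatter) as the changes from the saturated groups. The earlier compounds shown here showed that benzyl at this carbon lowers the number, but not that a further lowering was possible. The change to a six-membered aromatic ring bound directly to this carbon and carrying a methyl goes further, with a 2.1-fold lower number from compound 3 to compound 4 (0.32 log units; beyond the scatter) in the same assay. Nothing available gives a reason for these differences.

From the compounds shown here alone, it remains open whether the lowering belongs to the directly bound aromatic ring or to its methyl. Going by these compounds, it also remains open how a plain phenyl, a 4-chlorophenyl or a pyridine ring would read at this carbon.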